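The compounds below may be only part of what the source reports. "The series", "measured", "known", "first", "only" and "open" are said of these compounds alone.

Compound 3 `COc1ccc(-n2nncc2CN2C(=O)C3(C(C#N)=C(N)Oc4c(N)cc5nc6ccccc6nc5c43)c3ccccc32)cc1` stands at a limit: in a functional assay on HCT-116 cells (Homo sapiens) for antiproliferative activity, read by MTT assay, with a stated time of 48 h (on this read-out lower numbers stand for stronger inhibition and higher numbers for weaker inhibition), compound 3 gives > 50000 nM, a limit of the assay rather than a number. The same holds for its two neighbours. Compound 1 `N#CC1=C(N)Oc2c(c3nc4ccccc4nc3c3ccccc23)C12C(=O)N(Cc1cnnn1-c1ccccc1Cl)c1ccccc12` gives > 50000 nM, again a limit. Compound 2 `CCOc1ccc(-n2nncc2CN2C(=O)C3(C(C#N)=C(N)Oc4c3c3nc5ccccc5nc3c3ccccc43)c3ccccc32)cc1` gives > 50000 nM, also a limit. For the measured compounds named here, the one single-point step among them, a step that the two limits leave unreadable from compound 1 to compound 2, is therefore unreadable, because of the limit of > 50000 nM in this assay, at which 3 of the 3 values shown sit. Compound 4 `N#CC1=C(N)Oc2c(N)cc3nc4ccccc4nc3c2C12C(=O)N(Cc1cnnn1-c1ccc([N+](=O)[O-])cc1[N+](=O)[O-])c1ccccc12` differs from compound 3 by 2,4-dinitrophenyl in place of 4-methoxyphenyl on an aromatic nitrogen. Going by the values given here, no measured step bears on this change, so the expectation rests on the three limits alone; compound 4 is expected to remain at the limit, the expected step being a step that the limit leaves unreadable from compound 3 to compound 4. The estimate for compound 4 is 80000 nM, between 30000 nM and 300000 nM.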

Compound 4, half-maximal inhibitory concentration: 23900 nM
Estimate against measurement, compound 4: 3.3-fold (0.52 log units) above; measured number outside the range, below it.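

With 2,4-dinitrophenyl in place of 4-methoxyphenyl on the aromatic nitrogen, this assay shows an at least 2.0-fold lower number from compound 3 to compound 4 (0.32 log units; beyond the scatter). This position can therefore move the read-out on the core shared by these two compounds, which the earlier limits could not show, and the step from compound 1 to compound 2 cannot be read. The full size of the new step stays unknown because one end of it is a limit: the limit of > 50000 nM in this assay, at which 3 of the 4 values shown sit.

As far as these compounds go, it remains open whether a single nitro group or an amine on that phenyl ring would lower the number too. From the compounds shown here alone, it is also open whether the same change would do so on the core of compound 1.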